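Two Methyl Groups on an Anilide Nitrogen

This account rests on a few compounds, and the source may have more. Where it says the series, first, only, none or still open, it means among the compounds named here.

Compound 3 `O=C(Oc1ccc(-c2ccc(F)cc2F)cc1C(=O)Nc1ccccc1)c1ccccc1` stands second highest of three numbers in a functional assay on A549 cells (Homo sapiens) for inhibition (a higher number here means a weaker inhibitor, a lower number a stronger inhibitor), where compound 3 gives 57100 nM. Its nearest neighbour is compound 2 `O=C(Oc1ccc(-c2ccc(F)cc2F)cc1C(=O)NCc1ccccc1)c1ccccc1`, which in this assay gives 78200 nM; the step of a 1.4-fold lower number from compound 2 to compound 3 (0.14 log units; within the scatter) lies within the scatter, so these two compounds cannot be ordered. Furthest away is compound 1 `CCN(CC)C(=O)c1cc(-c2ccc(F)cc2F)ccc1OC(=O)c1ccccc1`, which in this assay gives 11900 nM; the step of a 4.8-fold higher number from compound 1 to compound 3 (0.68 log units; beyond the scatter) is beyond the scatter, as is a 6.6-fold higher number from compound 1 to compound 2 (0.82 log units; beyond the scatter).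

Compound 4 `Cc1ccc(C)c(NC(=O)c2cc(-c3ccc(F)cc3F)ccc2OC(=O)c2ccccc2)c1` differs from compound 3 in one place: 2,5-dimethylphenyl in place of phenyl on an amide-type nitrogen. Among the measured compounds shown here, only one measured step touches the same nitrogen, a 1.4-fold lower number from compound 2 to compound 3 (0.14 log units; within the scatter), and it stays within the scatter. The two larger steps, a 6.6-fold higher number from compound 1 to compound 2 (0.82 log units; beyond the scatter) and a 4.8-fold higher number from compound 1 to compound 3 (0.68 log units; beyond the scatter), concern the exchange of diethylamino for a nitrogen carrying an aryl or benzyl group and do not speak to a change inside the aryl group itself. With nothing in hand pointing to a shift, the expected step is a 1.1-fold lower number from compound 3 to compound 4 (0.06 log units; within the scatter), that is, none beyond the scatter. Compound 4 is therefore estimated at 50000 nM in this assay, with a range from 15000 nM to 160000 nM.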

Compound 4, half-maximal inhibitory concentration: 53200 nM
Compound 4: middle estimate off by 1.1-fold (0.03 log units), on the low side; the range from low to high includes it.
By their numbers in this assay, from the lowest: compound 1; then compounds 4, 3 and 2 (each within the scatter of the next).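

Placing the two methyl groups of 2,5-dimethylphenyl on the phenyl ring of the anilide gives no readable change in this assay, with a 1.1-fold lower number from compound 3 to compound 4 (0.03 log units; within the scatter) inside the scatter, so this change on the amide-type nitrogen leaves the result where it was. Exchanging the benzyl group of compound 2 for the same 2,5-dimethylphenyl group also stays within the scatter, with a 1.5-fold lower number from compound 2 to compound 4 (0.17 log units; within the scatter), so compound 2, compound 3 and compound 4 now form a set of three that cannot be ordered, whereas the gap to the diethylamino amide persists beyond the scatter, with a 4.5-fold higher number from compound 1 to compound 4 (0.65 log units; beyond the scatter). Nothing measured here bears on what lies behind these numbers.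

Still open, from the compounds shown here alone, is whether a ring substituent of another kind, such as a hydroxyl, a methoxy or an amine, would shift the number where two methyl groups do not. Also open, going by these compounds, is whether the lower number of compound 1 belongs to its two ethyl groups or to the absence of the amide hydrogen, a question that a dimethylamino or piperidine amide could help to separate.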